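Swapping bromo for methoxy on a second core

A few compounds are considered here, and "the series" means these few. Any claim that something is new, unique, unknown or untested is made for them only; others in the source may bear on it.

Measured so far in a functional assay on A549 cells (Homo sapiens) for antiproliferative activity, read by MTT assay, with a stated time of 72 h; on this read-out lower numbers stand for stronger inhibition and higher numbers for weaker inhibition:
- compound 1 `O=C(Nc1ccc(Oc2ccnc3[nH]ccc23)c(F)c1)c1cc2cccnc2n(-c2ccc(Br)cc2)c1=O` gives 210 nM
- compound 2 `COc1ccc(-n2c(=O)c(C(=O)Nc3ccc(Oc4ccnc5[nH]ccc45)c(F)c3)cc3cccnc32)cc1` gives 610 nM
- compound 3 `Cn1ccc2c(Oc3ccc(NC(=O)c4cc5cccnc5n(-c5ccc(Br)cc5)c4=O)cc3F)ccnc21` gives 390 nM

Compound 1 and compound 2 differ in one group, described as methoxy in place of bromo on an aromatic carbon. That change gave a 2.9-fold higher number from compound 1 to compound 2 (0.46 log units; beyond the scatter), a loss of potency that lies beyond the usual scatter.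

Compound 3 carries a different core from compound 1; the two cores differ as methyl in place of hydrogen on an aromatic nitrogen. This change gave a 1.9-fold higher number from compound 1 to compound 3 (0.27 log units; within the scatter), which lies within the scatter, so the two cores look roughly equal on this read-out.

Compound 4 `COc1ccc(-n2c(=O)c(C(=O)Nc3ccc(Oc4ccnc5c4ccn5C)c(F)c3)cc3cccnc32)cc1` has not yet been measured. It stands to compound 3 as compound 2 stands to compound 1: the difference is methoxy in place of bromo on an aromatic carbon, the same change at the same kind of place. The expectation is that compound 4 repeats the step already seen from compound 1 to compound 2, giving an estimated 2.8-fold higher number from compound 3 to compound 4 (0.45 log units; beyond the scatter) in this assay, resting on a 2.9-fold higher number from compound 1 to compound 2 (0.46 log units; beyond the scatter) and on the value of compound 3, 390 nM. Compound 4 is therefore estimated at 1100 nM, with a range from 500 nM to 2500 nM.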

Compound 4, half-maximal inhibitory concentration: 2750 nM
Beside the measured number, compound 4's estimate is 2.5-fold (0.40 log units) below it; measured number outside the range, above it.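

Replacing 4-bromophenyl with 4-methoxyphenyl again costs potency in this assay, with a 7.1-fold higher number from compound 3 to compound 4 (0.85 log units; beyond the scatter), so the direction of the change carries over from the core of compound 1 to the core of compound 3, and its size on the two cores cannot be told apart: the same change on two cores in this assay, a 2.9-fold higher number (0.46 log units; beyond the scatter) from compound 1 to compound 2 and a 7.1-fold higher number (0.85 log units; beyond the scatter) from compound 3 to compound 4, 2.4-fold (0.39 log units) apart, within the scatter of two such steps. Read the other way, placing a methyl on the aromatic nitrogen gives a 4.5-fold higher number from compound 2 to compound 4 (0.65 log units; beyond the scatter), and this step also cannot be separated from its counterpart in the bromo pair: the same change on two cores in this assay, a 1.9-fold higher number (0.27 log units; within the scatter) from compound 1 to compound 3 and a 4.5-fold higher number (0.65 log units; beyond the scatter) from compound 2 to compound 4, 2.4-fold (0.39 log units) apart, within the scatter of two such steps. Among these compounds, these four compounds cover only two cores and one swap, so they do not prove that the steps are truly equal in size, do not explain why methoxy gives the weaker result, and do not predict the change on any other core.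

Going by these compounds, it remains open whether other groups at the same place, such as chloro or an amine, would follow the same trend on both cores. On these data alone, it is also open whether an ethyl or a longer chain on the aromatic nitrogen would behave like the methyl.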